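Nitrophenyl Analogues in a Rat Paw Edema Study

The compounds below may be only part of what the source reports. "The series", "measured", "known", "first", "only" and "open" are said of these compounds alone.

Compound 1 `COc1ccc(C2CC(c3ccc(NC(=O)c4cc(Cl)ccc4OC)cc3)=NN2C)cc1`: 88.1%
Compound 2 `COc1ccc(Cl)cc1C(=O)Nc1ccc(C2=NN(C)C(c3ccccc3[N+](=O)[O-])C2)cc1`: 96.5%
Compound 3 `COc1ccc(C2CC(c3ccc(NC(=O)c4cc(Cl)ccc4OC)cc3)=NN2C(C)=O)cc1`: 86%

In a functional assay on the whole organism (strain albino) with Rattus norvegicus as the target, read by paw edema, with stated times of 1 h and 4 h, at a dose of 25 mg/kg by the oral route (a lower number here means a weaker effect, a higher number a stronger effect of the compound at the dose given), compound 1 gives 88.1%, compound 2 gives 96.5% and compound 3 gives 86%. Compound 2 carries 2-nitrophenyl in place of 4-methoxyphenyl on a saturated ring carbon relative to compound 1, giving a number 8.4 percentage points higher from compound 1 to compound 2 (within the scatter). Compound 3 differs from compound 1 by acetyl in place of methyl on an amine nitrogen in a ring, giving a number 2.1 percentage points lower from compound 1 to compound 3 (within the scatter).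

Compound 4 `COc1ccc(Cl)cc1C(=O)Nc1ccc(C2=NN(C(C)=O)C(c3ccccc3[N+](=O)[O-])C2)cc1` has not yet been measured in this assay. It carries 2-nitrophenyl in place of 4-methoxyphenyl on a saturated ring carbon relative to compound 3. This is the same kind of change as that made on compound 1, but here the saturated ring carbon sits next to the ring atom that bears an acetyl group, not next to the ring atom that bears a methyl group. Because a number 8.4 percentage points higher from compound 1 to compound 2 (within the scatter) was seen, a step of a number 6 percentage points higher from compound 3 to compound 4 (within the scatter) is expected here. Compound 4 is therefore estimated at 92%, between 80% and 100%.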

Compound 4, a percentage reported as activity, at one dose (the size of the read-out at that dose, not a potency): 92.2%
The estimate for compound 4 lay 0.2 percentage points below the measured number; measured number inside the range.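

In this assay, 2-nitrophenyl in place of 4-methoxyphenyl gives a number 6.2 percentage points higher from compound 3 to compound 4 (within the scatter), in line with the earlier step on the core of compound 1: the same change on two cores in this assay, a number 8.4 percentage points higher (within the scatter) from compound 1 to compound 2 and a number 6.2 percentage points higher (within the scatter) from compound 3 to compound 4, 2.2 percentage points apart, within the scatter of two such steps. Acetyl in place of methyl gives a number 4.3 percentage points lower from compound 2 to compound 4 (within the scatter), and this too agrees with the earlier step: the same change on two cores in this assay, a number 2.1 percentage points lower (within the scatter) from compound 1 to compound 3 and a number 4.3 percentage points lower (within the scatter) from compound 2 to compound 4, 2.2 percentage points apart, within the scatter of two such steps. Each change therefore carries from one core to the other without a detectable difference, but since every step lies within the scatter, this does not show that either change has a real effect of its own, and a single dose says nothing about potency. The compounds shown leave open whether this agreement extends to other groups, such as an aminophenyl on the saturated ring carbon or a longer acyl chain on the ring nitrogen.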